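The source may report more compounds than this note shows. Statements on the series, on what has been measured and on what is new or still open speak of the compounds shown alone.

Series notes. The shared core is carried unchanged through compound 1 `O=S1(=O)CC(Nc2nonc2/C(=N/O)Nc2ccc(F)c(Br)c2)C1`, compound 2 `CN(C)S(=O)(=O)CCNc1nonc1/C(=N/O)Nc1ccc(F)c(Br)c1` and compound 3 `C#CCNS(=O)(=O)CCNc1nonc1/C(=N/O)Nc1ccc(F)c(Br)c1`; the three differ only in the chain attached to the nitrogen on the aromatic ring. In an assay on isolated protein for inhibition of Indoleamine 2,3-dioxygenase 1 (Homo sapiens), read by fluorescence, with a stated time of 60 min (a lower number here means a stronger inhibitor, a higher number a weaker inhibitor), compound 1 gives 99 nM, compound 2 gives 105 nM, and compound 3 gives 218 nM. Compound 3 therefore has the highest of the three numbers: a 2.1-fold higher number from compound 2 to compound 3 (0.32 log units; beyond the scatter) and a 2.2-fold higher number from compound 1 to compound 3 (0.34 log units; beyond the scatter), whereas a 1.1-fold higher number from compound 1 to compound 2 (0.03 log units; within the scatter). The next compound, compound 4 `CN(C)S(=O)(=O)CCCNc1nonc1/C(=N/O)Nc1ccc(F)c(Br)c1`, has not yet been measured in this assay. Its change from compound 3 is (dimethylsulfamoyl)methyl in place of propargylsulfamoyl on a saturated chain carbon, two bonds along the chain from a nitrogen on an aromatic ring. In effect the dimethylsulfamoyl end of compound 2 returns, now on a chain one carbon longer. Among the compounds with values here, the measured step that bears most directly is a 2.1-fold higher number from compound 2 to compound 3 (0.32 log units; beyond the scatter), which the present change runs backwards; no measured pair isolates the effect of the longer chain on its own, so that part is unknown. The expectation for compound 4 is therefore a modest move to a lower number, a 2.0-fold lower number from compound 3 to compound 4 (0.30 log units; within the scatter), with the number for compound 4 expected to return toward that of compound 2. Compound 4 is estimated at 110 nM, within a range of 50 nM to 250 nM.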

Compound 4, half-maximal inhibitory concentration: 97 nM
The estimate for compound 4 lay 1.1-fold (0.05 log units) above the measured number, within the range that was stated.
By their numbers in this assay, from the lowest: compounds 4, 1 and 2 (each within the scatter of the next); then compound 3.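

Working notes on compound 4. In this assay, the sulfonyl end matters more than the added chain carbon: 3-(dimethylsulfamoyl)propyl in place of 2-(propargylsulfamoyl)ethyl gives a 2.2-fold lower number from compound 3 to compound 4 (0.35 log units; beyond the scatter) and the step is modest, whereas lengthening 2-(dimethylsulfamoyl)ethyl to 3-(dimethylsulfamoyl)propyl gives a 1.1-fold lower number from compound 2 to compound 4 (0.03 log units; within the scatter) and shows no separation between the two chain lengths. The open chain of compound 4 also stands level with the four-membered ring of compound 1 at a 1.0-fold lower number from compound 1 to compound 4 (0.01 log units; within the scatter) so this position accepts both the ring and the longer open chain without a readable change in the number. No information is available that accounts for these numbers.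

Still open, from the compounds shown here alone, is whether the tolerance for chain length extends to a longer chain such as 4-(dimethylsulfamoyl)butyl, and whether propargylsulfamoyl would keep its higher number on the propyl chain. Also open, going by these compounds, is how the series would respond to a different end group on the chain, such as a carboxylic acid or a morpholine sulfonamide.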